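Replacing 4-hydroxyphenyl with 2,3-dichlorophenyl in compound 3

This account rests on a few compounds, and the source may have more. Where it says the series, first, only, none or still open, it means among the compounds named here.

In an ADME assay on NHDF cells (Homo sapiens) for cytotoxicity, read by MTT assay, with a stated time of 72 h (a lower number here means a stronger inhibitor, a higher number a weaker inhibitor), compound 1 `COc1cccc(/C=C2\CCC/C(=C\c3cccc(OC)c3OC)C2=O)c1` gives 16400 nM and compound 2 `COc1ccc(/C=C2\CCC/C(=C\c3cccc(OC)c3OC)C2=O)cc1` gives 43500 nM. The difference between these two is a 2.7-fold higher number from compound 1 to compound 2 (0.42 log units; beyond the scatter). Compound 3 `COc1cccc(/C=C2\CCC/C(=C\c3ccc(O)cc3)C2=O)c1OC` has only a limit, > 50000 nM, and no exact number.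

Compound 4 `COc1cccc(/C=C2\CCC/C(=C\c3cccc(Cl)c3Cl)C2=O)c1OC` carries 2,3-dichlorophenyl in place of the 4-hydroxyphenyl of compound 3, on a double-bonded chain carbon bound to a double-bonded ring carbon. The counted difference is 2,3-dichlorophenyl in place of 4-hydroxyphenyl on a double-bonded chain carbon bound to a double-bonded ring carbon. Among the measured compounds shown here, two measured steps bear on this place. One is an at least 3.0-fold higher number from compound 1 to compound 3 (0.48 log units; beyond the scatter), and the other is an at least 1.1-fold higher number from compound 2 to compound 3 (0.06 log units; that floor lies within the scatter), whose floor lies within the scatter. Neither involves 2,3-dichlorophenyl, so they guide the expectation only loosely. Taking an at least 3.0-fold higher number from compound 1 to compound 3 (0.48 log units; beyond the scatter) as the closest guide, a modest move towards a lower number is expected, though a second result at the limit remains possible. The expected change is an at least 2.5-fold lower number from compound 3 to compound 4 (0.39 log units; beyond the scatter). For compound 4 the estimate is 20000 nM, with an expected range from 6000 nM to 50000 nM.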

Compound 4, half-maximal inhibitory concentration: > 50000 nM
Compound 4: only a limit was reported; the forecaster's own chance of this, stated with the estimate: 20%; middle value at least 2.5-fold (0.39 log units) away from the limit.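

In this assay compound 4 gives > 50000 nM, which is a limit of the assay and not a number, so 2,3-dichlorophenyl at this place yields no exact value, just as 4-hydroxyphenyl did. Against 3-methoxyphenyl, the change to 2,3-dichlorophenyl gives an at least 3.0-fold higher number from compound 1 to compound 4 (0.48 log units; beyond the scatter), whereas against 4-methoxyphenyl it gives an at least 1.1-fold higher number from compound 2 to compound 4 (0.06 log units; that floor lies within the scatter), which leaves compound 1 with the lowest number of the four. The step between compound 3 and compound 4 cannot be read, because both rest on the same limit: the limit of > 50000 nM in this assay, at which 2 of the 4 values shown sit.

On these data alone, how far compound 3 and compound 4 actually differ therefore stays open. So does whether an amine or a carboxylic acid on the phenyl ring at this place would give a number within the range of the assay.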